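The source may report more compounds than this note shows. Statements on the series, on what has been measured and on what is new or still open speak of the compounds shown alone.

Compound 1 `O=C(Nc1cccc(-n2cc(-c3ccncc3)c(-c3ccc(Cl)c(O)c3)n2)c1)Nc1ccc(Cl)c(Cl)c1`: > 32500 nM
Compound 2 `COc1cc(-c2nn(-c3cccc(NC(=O)Nc4cccc(C(F)(F)F)c4)c3)cc2-c2ccncc2)ccc1Cl`: > 50000 nM

In a functional assay on NCI-H322M cells (Homo sapiens) for inhibition, read by sulforhodamine B assay, with a stated time of 48 h (on this read-out lower numbers stand for higher toxicity in this test and higher numbers for lower toxicity in this test), compound 1 gives > 32500 nM, which is a limit of the assay and not a number (the limit of > 32500 nM in this assay, at which 1 of the 2 values shown sits). In this assay compound 2 gives > 50000 nM, likewise a limit and not a number (the limit of > 50000 nM in this assay, at which 1 of the 2 values shown sits). Compound 1 thus stands at a limit, with no number of its own. Compound 3 `O=C(Nc1cccc(-n2cc(-c3ccncc3)c(-c3ccc(Cl)c(O)c3)n2)c1)Nc1ccc(Cl)c(C(F)(F)F)c1` has not been measured. From compound 1 to compound 3 the change is trifluoromethyl in place of chloro on an aromatic carbon. Among the compounds with values here, with no measured step to lean on, the step from compound 1 to compound 3 is expected to stay within the scatter, and compound 3 is expected to come out as a limit again. The expected step is a step that the limit leaves unreadable from compound 1 to compound 3. The estimate for compound 3 is 40000 nM, between 20000 nM and 100000 nM.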

Compound 3, concentration lethal to 50% of the cells: 24700 nM
Estimate against measurement, compound 3: 1.6-fold (0.21 log units) above, within the range that was stated.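

In this assay compound 3 is the only compound shown that gives a number, 24700 nM. With trifluoromethyl in place of chloro, on the carbon ortho to a chloro group, the result is an at least 1.3-fold lower number from compound 1 to compound 3 (0.11 log units; that floor lies within the scatter). So no real change can be claimed, and the true size of the step stays unknown because compound 1 stands at a limit of the assay and not at a number: the limit of > 32500 nM in this assay, at which 1 of the 3 values shown sits.

As far as these compounds go, what a nitrile or an amine on this same carbon would give remains open. So does whether removing the chloro group ortho to it would alter the reading.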